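Ethyl to methyl on the hydroxy-bearing nitrogen: compound 3

A few compounds are considered here, and "the series" means these few. Any claim that something is new, unique, unknown or untested is made for them only; others in the source may bear on it.

Measured so far:
Compound 1 `CCCNC(=O)N(O)c1cc([C@H]2CC[C@H](c3cc(OC)c(OC)c(OC)c3)O2)cc(OCCC)c1OCCC`: in a functional assay on RBL-2H3 cells for inhibition of Polyunsaturated fatty acid 5-lipoxygenase (Rattus norvegicus) (on this read-out lower numbers stand for stronger inhibition and higher numbers for weaker inhibition), compound 1 gives 3000 nM.
Compound 2 `CCCOc1cc([C@H]2CC[C@H](c3cc(OC)c(OC)c(OC)c3)O2)cc(N(CC)C(=O)N(O)CC)c1OCCC`: in this assay compound 2 gives 1340 nM.

Going by the values given here, compound 2 stands lowest of the two numbers; its only neighbour is compound 1, and the step of a 2.2-fold lower number from compound 1 to compound 2 (0.35 log units; beyond the scatter) is the single measured step. That step swaps groups on both nitrogens of the urea-type unit at once, so it does not isolate a change at either nitrogen.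

Compound 3 `CCCOc1cc([C@H]2CC[C@H](c3cc(OC)c(OC)c(OC)c3)O2)cc(N(CC)C(=O)N(C)O)c1OCCC` keeps the core of compound 2 and differs only by hydrogen in place of methyl on a saturated chain carbon bound to an amide-type nitrogen. Among the compounds with values here, no measured pair tracks this kind of single-carbon trimming on the saturated chain at the amide-type nitrogen; the step from compound 1 to compound 2 bears on it only loosely, since it also removed a carbon from the chain on the hydroxy-bearing nitrogen while adding one elsewhere. Given that, the expected step is a 1.1-fold higher number from compound 2 to compound 3 (0.05 log units; within the scatter), not beyond the scatter in either direction. The estimate for compound 3 in this assay is 1500 nM, with a range from 500 nM to 4500 nM.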

Compound 3, half-maximal inhibitory concentration: 3070 nM
For compound 3 the middle estimate is 2.0-fold (0.31 log units) below the measured one; the range from low to high includes it.
By their numbers in this assay, from the lowest: compound 2; then compounds 1 and 3 (each within the scatter of the next).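

Working notes on the series. In this assay, going by these compounds alone, the change from ethyl(hydroxy)carbamoyl to hydroxy(methyl)carbamoyl gives a 2.3-fold higher number from compound 2 to compound 3 (0.36 log units; beyond the scatter), the first read of a change at this one place alone, and it shows that a single carbon on this saturated chain is enough to move the number beyond the scatter. The second comparison, a 1.0-fold higher number from compound 1 to compound 3 (0.01 log units; within the scatter), places ethyl(hydroxy(methyl)carbamoyl)amino and hydroxy(propylcarbamoyl)amino within the scatter of each other, so the advantage in a 2.2-fold lower number from compound 1 to compound 2 (0.35 log units; beyond the scatter) does not survive once ethyl gives way to methyl at this place. Nothing available explains why one carbon at this place carries this step.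

Only methyl and ethyl have been compared at this place, so two points define no trend, and a butyl chain or a cyclopropyl group there could continue the direction of the step, level off or reverse it. From the compounds shown here alone, it also remains open whether the same carbon counts equally with a group other than ethyl on the nitrogen bound to the aromatic carbon, such as a methyl group or a plain hydrogen.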